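Swapping a Pyrimidin-2-yl Group for Cyclopropylcarbonyl

A few compounds are considered here, and "the series" means these few. Any claim that something is new, unique, unknown or untested is made for them only; others in the source may bear on it.

Compound 1 `O=C(Cn1cnc([N+](=O)[O-])n1)N1CCN(c2ncccn2)CC1` was tested in an ADME assay on L6 cells (Rattus norvegicus) for cytotoxicity (on this read-out higher numbers stand for weaker inhibition and lower numbers for stronger inhibition), and gives 150000 nM. Among three compounds it has the second highest number: compound 3 `O=C(Cn1cnc([N+](=O)[O-])n1)N1CCN(c2ccc(C(F)(F)F)cc2)CC1` gives 202000 nM, a difference within the scatter, while compound 2 `O=C(CN1CCN(c2ccc(Cl)c(Cl)c2)CC1)N1CCN(c2ccc(Cl)c(Cl)c2)CC1` gives 20200 nM, a lower number beyond the scatter. Compound 4 `O=C(Cn1cnc([N+](=O)[O-])n1)N1CCN(C(=O)C2CC2)CC1` has not yet been measured in this assay. It differs from compound 1 in one place: cyclopropylcarbonyl in place of pyrimidin-2-yl on an amine nitrogen in a ring. Within the data shown here, no measured pair shows this change, so its effect is unknown. The step of a 1.2-fold higher number from compound 1 to compound 4 (0.08 log units; within the scatter) is expected to be small, none beyond the scatter, because compound 1 gives 150000 nM and the closely related compound 3 gives 202000 nM. Compound 4 is therefore expected to give 180000 nM, in a range from 80000 nM to 400000 nM.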

Compound 4, half-maximal inhibitory concentration: 156000 nM
For compound 4 the middle estimate is 1.2-fold (0.06 log units) above the measured one; the measured number falls inside the stated range.
By their numbers in this assay, from the lowest: compound 2; then compounds 1, 4 and 3 (each within the scatter of the next).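

Among these compounds, putting cyclopropylcarbonyl in place of pyrimidin-2-yl on the ring amine nitrogen gives a 1.0-fold higher number from compound 1 to compound 4 (0.02 log units; within the scatter) in this assay and is the first single-place comparison at this position. Here, a six-membered aromatic ring with two nitrogens and a carbonyl-linked three-membered carbon ring give numbers within the scatter of each other. No measurement shown here explains this result.

On these data alone, whether a carboxylic acid, an amine or a longer alkyl chain on this nitrogen would also stay within the scatter remains open. So does whether this swap gives a similar step on a different core.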